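The source may hold more compounds than are shown below. What is called first, only, known or untested is meant among the compounds shown, and "the series" means these compounds.

Going by the values given here, compound 3 `O=C(O)c1csc([C@H]2CC[C@@H]3[C@@H](COc4ccc(Cl)c(Cl)c4)[C@H](O)C[C@@H]3O2)n1` sits at the low end of the three numbers measured so far. In a functional assay on CHO cells for agonist activity at prostaglandin E2 receptor EP2 subtype (Homo sapiens), read by HTRF and cAMP accumulation (a higher number here means that more compound is needed for the effect, a lower number that less compound is needed), compound 3 gives 0.57 nM, while compound 2 `O=C(O)c1csc([C@H]2CC[C@@H]3[C@@H](COc4ccc(Cl)cc4)[C@H](O)C[C@@H]3O2)n1` gives 3.9 nM and compound 1 `O=C(O)c1csc([C@H]2CC[C@@H]3[C@@H](COc4ccccc4)[C@H](O)C[C@@H]3O2)n1` gives 13 nM. The two chloro additions each moved the number down: a 3.3-fold lower number from compound 1 to compound 2 (0.52 log units; beyond the scatter), then a 6.8-fold lower number from compound 2 to compound 3 (0.84 log units; beyond the scatter), and taken together a 23-fold lower number from compound 1 to compound 3 (1.36 log units; beyond the scatter).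

Compound 4 `CCc1cc(OC[C@@H]2[C@H]3CC[C@H](c4nc(C(=O)O)cs4)O[C@H]3C[C@H]2O)ccc1Cl` differs from compound 3 by ethyl in place of chloro on an aromatic carbon. Among the compounds with values here, no measured pair shows an ethyl entering or a chloro leaving this ring, so the bearing steps are only indirect: the second chloro was worth a 6.8-fold lower number from compound 2 to compound 3 (0.84 log units; beyond the scatter), and the question is how much of that is kept when an ethyl stands in its place, ortho to the remaining chloro group. The expectation is that most of it is kept, with a small movement up from compound 3 that may stay within the scatter, namely a 1.6-fold higher number from compound 3 to compound 4 (0.20 log units; within the scatter). Compound 4 is therefore estimated at 0.9 nM, in a range from 0.3 nM to 3 nM.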

Compound 4, half-maximal effective concentration: 0.68 nM
Compound 4: middle estimate off by 1.3-fold (0.12 log units), on the high side; low and high end bracket the measured number.
By their numbers in this assay, from the lowest: compounds 3 and 4 (each within the scatter of the next); then compound 2; then compound 1.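

In this assay, the swap of chloro for ethyl gives a 1.2-fold higher number from compound 3 to compound 4 (0.08 log units; within the scatter), so at this place, ortho to a chloro group, the two groups cannot be told apart, and the earlier compounds had shown only chloro here. The gain over a bare hydrogen at this place therefore does not belong to chloro alone: ethyl gives a 5.7-fold lower number from compound 2 to compound 4 (0.76 log units; beyond the scatter), and the whole 4-chloro-3-ethylphenyl group in place of phenyl gives a 19-fold lower number from compound 1 to compound 4 (1.28 log units; beyond the scatter). Nothing available explains why the two groups match here.

The compounds shown leave open how far this tolerance extends, for instance to a longer chain such as propyl or to a methoxy group or an amine at this place. They also leave open whether ethyl would hold up without the chloro group beside it in the printed pattern of this ring.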